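A few compounds are considered here, and "the series" means these few. Any claim that something is new, unique, unknown or untested is made for them only; others in the source may bear on it.

Compound 1 `Nc1cc(N)c2nc(-c3ccccc3)c(NCc3ccc(F)cc3)nc2c1` gives in a functional assay on HOP-62 cells (Homo sapiens) for inhibition, read by sulforhodamine B assay, with a stated time of 48 h (on this read-out lower numbers stand for stronger inhibition of growth and higher numbers for weaker inhibition of growth), only the limit < 100000 nM.
Compound 2 `COc1ccc(Sc2nc3cc(N)cc(N)c3nc2-c2ccccc2)cc1` gives in this assay only the limit < 100000 nM.
Compound 3 `Nc1cc(N)c2nc(-c3ccccc3)c(Oc3ccc(F)cc3)nc2c1` gives in this assay the value 49000 nM.

Going by the values given here, compound 3 thus stands as the only real number among the three, the other two sitting at the limit (the limit of < 100000 nM in this assay, at which 2 of the 3 values shown sit). Compound 4 `Nc1cc(N)c2nc(-c3ccccc3)c(Sc3ccc(F)cc3)nc2c1` differs from compound 3 by (4-fluorophenyl)sulfanyl in place of 4-fluorophenoxy on an aromatic carbon. Among the compounds with values here, the steps that end at compound 3, a step that the limit leaves unreadable from compound 1 to compound 3 and a step that the limit leaves unreadable from compound 2 to compound 3, as well as a step that the two limits leave unreadable from compound 1 to compound 2, give no readable size, so no measured step bears on this exchange. The expectation therefore rests on compound 3 alone, with a wide spread. Compound 4 is expected to give 45000 nM, between 12000 nM and 150000 nM. This estimate corresponds to a step of a 1.1-fold lower number from compound 3 to compound 4 (0.04 log units; within the scatter), expected to lie within the scatter.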

Compound 4, concentration for total growth inhibition: 34700 nM
For compound 4 the middle estimate is 1.3-fold (0.11 log units) above the measured one; low and high end bracket the measured number.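

Going by these compounds alone, at this aromatic carbon next to the ring nitrogen, (4-fluorophenyl)sulfanyl can replace 4-fluorophenoxy with a 1.4-fold lower number from compound 3 to compound 4 (0.15 log units; within the scatter) in this assay, which gives the first readable step at this position and shows no real change. The steps from compound 1 and compound 2 to compound 4 cannot be read, as each of those compounds gives only a limit: the limit of < 100000 nM in this assay, at which 2 of the 4 values shown sit.

As far as these compounds go, what a small amine or a carboxylic acid at this position would give stays open. So does whether chloro in place of the fluoro on this group would shift the number beyond the scatter.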